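Moving a Trifluoromethyl Group Around a Phenyl Ring

This account rests on a few compounds, and the source may have more. Where it says the series, first, only, none or still open, it means among the compounds named here.

From the compounds shown here alone, compound 2 `Oc1ccc(-c2cc(-c3ccccc3C(F)(F)F)cc(-c3ccc(O)cc3)n2)cc1` in a functional assay on T47D cells (Homo sapiens) for inhibition (a higher number here means a weaker inhibitor, a lower number a stronger inhibitor), gives only the limit > 50000 nM, so its exact strength is unknown. Compound 1 `Oc1ccc(-c2cc(-c3ccc(F)cc3)cc(-c3ccc(O)cc3)n2)cc1`, carrying a 4-fluorophenyl instead, gives 5260 nM in this assay. Going by the values given here, the one measured change bearing here is an at least 9.5-fold higher number from compound 1 to compound 2 (0.97 log units; beyond the scatter), and the limit of > 50000 nM in this assay, at which 1 of the 2 values shown sits, caps how large it can be read. Compound 3 `Oc1ccc(-c2cc(-c3ccc(C(F)(F)F)cc3)cc(-c3ccc(O)cc3)n2)cc1` differs from compound 2 by 4-(trifluoromethyl)phenyl in place of 2-(trifluoromethyl)phenyl on an aromatic carbon. Because compound 3 resembles compound 1 with its 5260 nM, a gain of an at least 6.2-fold lower number from compound 2 to compound 3 (0.79 log units; beyond the scatter) is expected. Compound 3 is therefore estimated at 8000 nM, between 2500 nM and 40000 nM.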

Compound 3, half-maximal inhibitory concentration: > 50000 nM
Compound 3 was reported as a limit (the forecaster's own chance of this, stated with the estimate: 20%); middle value at least 6.2-fold (0.79 log units) away from the limit.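

Moving the trifluoromethyl group does not bring the strength back: in this assay compound 3 gives > 50000 nM, which is a limit of the assay and not a number. Trifluoromethyl in place of fluoro gives an at least 9.5-fold higher number from compound 1 to compound 3 (0.97 log units; beyond the scatter), so the loss is not confined to 2-(trifluoromethyl)phenyl. The step between the two trifluoromethyl compounds cannot be read, as both sit at the same limit: the limit of > 50000 nM in this assay, at which 2 of the 3 values shown sit.

From the compounds shown here alone, it remains open how far compound 2 and compound 3 actually lie beyond that limit. Also open, going by these compounds, is how a methoxy or an amine in place of the fluoro of compound 1 would read.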